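From dimethylamino to methylpyrazole: estimating compound 3

The source may report more compounds than this note shows. Statements on the series, on what has been measured and on what is new or still open speak of the compounds shown alone.

Of the compounds shown here, two with a shared core have been measured so far in a functional assay on HeLa cells (Homo sapiens) for inhibition, read by CCK-8 assay, with a stated time of 48 h; on this read-out higher numbers stand for weaker inhibition and lower numbers for stronger inhibition. Compound 1 (`COc1cc(-c2ccnc3cc(-c4ccc(F)cc4)nn23)cc(OC)c1OC`) gives 5840 nM, and compound 2 (`COc1cc(-c2ccnc3cc(-c4ccc(N(C)C)cc4)nn23)cc(OC)c1OC`) gives 378 nM, the lower and therefore stronger of the two numbers. The unmeasured compound 3 (`COc1cc(-c2ccnc3cc(-c4ccc(-c5cnn(C)c5)cc4)nn23)cc(OC)c1OC`) keeps that core and changes one group: 1-methyl-1H-pyrazol-4-yl in place of dimethylamino on an aromatic carbon. A single measured step bears on this change, dimethylamino in place of fluoro at the same place, which is a 15-fold lower number from compound 1 to compound 2 (1.19 log units; beyond the scatter). That large step shows that a swap here can move the number a long way in this assay. Among the compounds with values here, it does not show what a pyrazole will do, since no measured compound carries one. The data favour no direction, so no step beyond the scatter is expected, though the margin on either side stays wide. The expected change is a 1.2-fold higher number from compound 2 to compound 3 (0.08 log units; within the scatter). For compound 3 the estimate is 450 nM, with an expected range from 90 nM to 2200 nM.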

Compound 3, half-maximal inhibitory concentration: 1830 nM
Estimate against measurement, compound 3: 4.1-fold (0.61 log units) below; the measured number falls inside the stated range.
By their numbers in this assay, from the lowest: compound 2; then compound 3; then compound 1.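

In this assay, 1-methyl-1H-pyrazol-4-yl in place of dimethylamino gives a 4.8-fold higher number from compound 2 to compound 3 (0.68 log units; beyond the scatter), so dimethylamino cannot be swapped for this ring at this aromatic carbon without a loss, even though the pyrazole brings more heavy atoms and one more hydrogen-bond acceptor. Measured against fluoro at the same place, the pyrazole still gives a gain, with a 3.2-fold lower number from compound 1 to compound 3 (0.50 log units; beyond the scatter), which means that the large drop in the number seen with dimethylamino is not unique to that group, although the pyrazole recovers only part of it. Nothing available here explains why the three groups fall in this order, and no separate measurement bears on it.

Within the data shown here, with only three groups to compare, it stays open whether the advantage of dimethylamino extends to other amines, such as a pyrrolidine or a morpholine, or to a simple methoxy group, any of which could sit at this same aromatic carbon. On these data alone, it also stays open whether a pyrazole without its methyl group, or one joined through a different ring atom, would behave like the 1-methyl-1H-pyrazol-4-yl group.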